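Chloro on the aryl ring of two related cores

This account rests on a few compounds, and the source may have more. Where it says the series, first, only, none or still open, it means among the compounds named here.

Four compounds are compared here, built on two different cores. Compound 1 `N/N=C1\NCCN1c1ccccc1` and compound 3 `N/N=C1\NCCN1c1cccc(Cl)c1` share one core; compound 2 `N=c1c(=O)[nH]nc2n1CCN2c1ccccc1` and compound 4 `N=c1c(=O)[nH]nc2n1CCN2c1ccc(Cl)cc1` share another. The difference between the two cores is not broken down here. All were looked at in an ADME assay on Vero cells (Chlorocebus sabaeus) for cytotoxicity, with a stated time of 72 h, tested at 50 ug/mL; on this read-out lower numbers stand for a weaker effect and higher numbers for a stronger effect at the one concentration tested. In this assay compound 1 gives 0%, compound 3 gives 10% and compound 2 gives 30%. Compound 2 gives the highest of the three numbers, and its steps to compound 3 and to compound 1 both lie beyond the scatter.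

From compound 1 to compound 3 the change is chloro in place of hydrogen on an aromatic carbon, and it made a number 10 percentage points higher from compound 1 to compound 3 (within the scatter). From compound 2 to compound 4 the change is chloro in place of hydrogen on an aromatic carbon, the same kind of change but not the same one: in compound 3 the chloro sits meta to a group of 7 heavy atoms, in compound 4 it sits para to a large group.

Compound 4 has not yet been measured. Since the same kind of change from compound 1 to compound 3 gave a number 10 percentage points higher from compound 1 to compound 3 (within the scatter), the step from compound 2 to compound 4 is expected to be about a number 5 percentage points higher from compound 2 to compound 4 (within the scatter). The number for compound 4 in this assay is therefore estimated at 35%, most likely between 15% and 55%.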

Compound 4, a percentage reported as inhibition, at one concentration (the size of the read-out at that concentration, not a potency): 0%
Compound 4: middle estimate off by 35 percentage points, on the high side, outside the stated range (below it).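

Swapping hydrogen for chloro on the aryl ring of the second core gave a number 30 percentage points lower from compound 2 to compound 4 (beyond the scatter) in this assay. The effect of this change therefore cannot simply be carried from one core to the other in this series, as the two steps set side by side show: the same change on two cores in this assay, a number 10 percentage points higher (within the scatter) from compound 1 to compound 3 and a number 30 percentage points lower (beyond the scatter) from compound 2 to compound 4, 40 percentage points apart, beyond the scatter of two such steps

What this does not show is that the core alone accounts for the gap: the chloro in compound 4 is para to a large group and does not sit in the same place as the chloro in compound 3, so core and position change together, and only these two pairs are available, each read at a single concentration.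

Among the compounds shown here, it remains open whether a chloro on the core of compound 2, placed as it is in compound 3, would follow the step seen with compound 3 or the one seen with compound 4, which would help separate the role of the core from that of the position. Also open, on these data alone, is whether another group in place of the chloro, such as a methoxy group, an amine or a carboxylic acid, would give steps that differ between the two cores in the same way.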